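Adding cyclohexyloxy to compound 1

The source may report more compounds than this note shows. Statements on the series, on what has been measured and on what is new or still open speak of the compounds shown alone.

In a physicochemical assay for lipophilicity, at pH 7.4 (a higher number here means a more lipophilic compound, a lower number a more polar compound), compound 1 (`CCc1ccc(N(CC(C)C)S(=O)(=O)c2ccc3c(c2)CCC(C2CCOCC2)O3)cc1`) gives 5.38 as the highest of three measured numbers. Compound 2 (`CCc1ccc(N(CC(C)C)S(=O)(=O)c2ccc3c(c2)CCC3OC2CCOCC2)cc1`) gives 4.96 and sits lower, a gap beyond the scatter. Compound 3 (`CCc1ccc(NS(=O)(=O)c2ccc3c(c2)C(O)CC(C2CCOCC2)O3)cc1`) gives 2.59 and sits lower still, again beyond the scatter. Among the measured compounds shown here, these three compounds differ in more than one place, so no measured pair isolates a single change.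

Compound 4 (`CCc1ccc(N(CC(C)C)S(=O)(=O)c2ccc3c(c2)C(OC2CCCCC2)CC(C2CCOCC2)O3)cc1`) keeps the core of compound 1 and carries cyclohexyloxy in place of hydrogen on a saturated ring carbon, two ring bonds from the ring atom that bears an oxan-4-yl group (cyclohexyloxy in place of hydrogen on a saturated ring carbon). For the measured compounds named here, with no measured step to compare, the expectation rests on the structural change alone, and a rise beyond the scatter is expected in this assay for this addition. The expected change is a number 0.92 log units higher from compound 1 to compound 4 (beyond the scatter) in this estimate. For compound 4 the estimated value is 6.3 with an expected range between 5.6 and 7 on the same scale.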

Compound 4, distribution coefficient: 6.28
Compound 4: the middle estimate sits 0.02 log units above what was measured; the range from low to high includes it.
By their numbers in this assay, from the lowest: compound 3; then compound 2; then compound 1; then compound 4.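

Among the compounds shown here, for the first time in this set a single change can be read on its own: with cyclohexyloxy in place of hydrogen on a saturated ring carbon, two ring bonds from the ring atom that bears an oxan-4-yl group, this assay shows a number 0.90 log units higher from compound 1 to compound 4 (beyond the scatter). This shows that the number responds to an addition at this position, which compound 2 and compound 3 could not show, as they differ from compound 1 in more than one place. Nothing available explains why the step has this size.

For the compounds shown here, one group at one position gives only one step, so whether a smaller group such as methoxy would give part of it stays open. Also open, as far as these compounds go, is whether an amine or a carboxylic acid on the same ring carbon would move the number in the opposite direction.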